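Chloro for Ethoxy: What Compound 4 Might Show

The compounds below may be only part of what the source reports. "The series", "measured", "known", "first", "only" and "open" are said of these compounds alone.

Measured compounds:
compound 1, `CCOc1cccc2cc(S(=O)(=O)Nc3ccc(OC)cc3)c(=O)oc12`, 78000 nM
compound 2, `CCOc1cccc2cc(S(=O)(=O)Nc3ccc(F)c(N)c3)c(=O)oc12`, 80000 nM
compound 3, `CCOc1cccc2cc(S(=O)(=O)Nc3ccc(Br)cc3)c(=O)oc12`, 85000 nM

In a functional assay on DLD-1 cells (Homo sapiens), with a stated time of 96 h (a higher number here means a weaker inhibitor of growth, a lower number a stronger inhibitor of growth), compound 3 gives the highest of the three numbers, but its gaps to the others are small: a 1.1-fold higher number from compound 1 to compound 3 (0.04 log units; within the scatter) and a 1.1-fold higher number from compound 2 to compound 3 (0.03 log units; within the scatter), both within the scatter, as is a 1.0-fold higher number from compound 1 to compound 2 (0.01 log units; within the scatter). The three compounds cannot be placed in any order on this assay.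

Compound 4, `O=c1oc2c(Cl)cccc2cc1S(=O)(=O)Nc1ccc(Br)cc1`, has not been measured. It differs from compound 3 by chloro in place of ethoxy on an aromatic carbon. Among the measured compounds shown here, every measured step changed the aryl group on the sulfonamide nitrogen; none altered this position on the shared core, so no measured step bears directly on the change. What the data do show is that three quite different sulfonamide aryl groups left the growth-inhibition value essentially unchanged, and that the common core itself appears to set the weak activity.

As far as these compounds go, compound 4 is therefore expected to land close to compound 3, with no change at the digits printed from compound 3 to compound 4 (within the scatter) as the estimated step, and a wider range than usual because the changed position is untested. The estimate for compound 4 in this assay is 85000 nM, between 30000 nM and 250000 nM.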

Compound 4, concentration for 50% growth inhibition: 18000 nM
Estimate against measurement, compound 4: 4.7-fold (0.67 log units) above, and the stated range ends above it.
By their numbers in this assay, from the lowest: compound 4; then compounds 1, 2 and 3 (each within the scatter of the next).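

In this assay, chloro in place of ethoxy on an aromatic carbon of the shared core goes with a 4.7-fold lower number from compound 3 to compound 4 (0.67 log units; beyond the scatter) and is the only step shown that lies beyond the scatter. Among the compounds shown here, this position, ortho to a fused ring and meta to a fused ring, can therefore move the growth-inhibition value, whereas the three aryl groups on the sulfonamide nitrogen of compounds 1, 2 and 3 could not be told apart, so the core substituent matters in a way the earlier compounds did not reveal. No measurement shown here offers an explanation for this step.

A single swap cannot separate the loss of ethoxy from the arrival of chloro, and a methoxy, a fluoro, a bromo, an amine or a plain hydrogen at this place would be needed to tell which of the two counts. As far as these compounds go, it also remains open whether chloro gives a step of similar size when the sulfonamide nitrogen carries the 4-methoxyphenyl of compound 1 or the 3-amino-4-fluorophenyl of compound 2, rather than the 4-bromophenyl of compound 3.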